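Chain extension from compound 3 to compound 4: working notes

The source may hold more compounds than are shown below. What is called first, only, known or untested is meant among the compounds shown, and "the series" means these compounds.

All three measured compounds were run in a functional assay on CHO cells with sphingosine 1-phosphate receptor 2 (Homo sapiens) as the target, read by GTPgammaS binding (on this read-out higher numbers stand for an effect only at larger amounts of compound and lower numbers for an effect already at smaller amounts), and each returned only the assay limit rather than a number:

compound 1 `Cc1ccccc1-c1noc(-c2ccc(C3CCCCC3)cc2)n1`: > 10000 nM, a limit of this assay
compound 2 `Cc1cc(C(=O)O)ccc1-c1noc(-c2ccc(C3CCCCC3)cc2)n1`: > 10000 nM, a limit of this assay
compound 3 `Cc1cc(CC(=O)O)ccc1-c1noc(-c2ccc(C3CCCCC3)cc2)n1`: > 10000 nM, a limit of this assay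

Compound 3 therefore stands at the limit, not at a measured value, and nothing places it relative to the others. The three one-place steps, a step that the two limits leave unreadable from compound 1 to compound 2, a step that the two limits leave unreadable from compound 1 to compound 3 and a step that the two limits leave unreadable from compound 2 to compound 3, are all of unreadable size for the same reason, (the limit of > 10000 nM in this assay, at which 3 of the 3 values shown sit).

Compound 4 `Cc1cc(CCCC(=O)O)ccc1-c1noc(-c2ccc(C3CCCCC3)cc2)n1` differs from compound 3 by 2-carboxyethyl in place of carboxy on a saturated chain carbon bound to an aromatic carbon. For the measured compounds named here, the only steps that bear on this change are those above, and none of them gives a readable size. Going from carboxy through carboxymethyl to 3-carboxypropyl, every measured member sits at the limit, so the expectation is that this change produces no step that can be read in this assay: the step from compound 3 to compound 4 is expected to be a step that the limit leaves unreadable from compound 3 to compound 4. Compound 4 is estimated at 20000 nM, with a range from 5000 nM to 80000 nM, most probably reported again only as a limit.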

Compound 4, half-maximal effective concentration: > 10000 nM
Compound 4: only a limit was reported; the forecaster's own chance of this, stated with the estimate: 85%; the middle value does not contradict the limit.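

No step from compound 1, compound 2 or compound 3 to compound 4 can be read in this assay, because all four compounds sit at the same limit: the limit of > 10000 nM in this assay, at which 4 of the 4 values shown sit.

The compounds shown leave open how the four compare, and whether any change to the shared core gives a measurable effect.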